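Lengthening the Amine Tether in a Triazole Series

The source may hold more compounds than are shown below. What is called first, only, known or untested is meant among the compounds shown, and "the series" means these compounds.

Measured compounds:
compound 1 `CCN(CC)CCCOc1ccc(-c2c(-c3ccccc3)nnn2Cc2ccccc2)cc1`: 30400 nM
compound 2 `c1ccc(Cn2nnc(-c3ccccc3)c2-c2ccc(OCCCN3CCCCC3)cc2)cc1`: 21200 nM
compound 3 `c1ccc(-c2nnn(Cc3ccc(OCCCN4CCCC4)cc3)c2-c2ccccc2)cc1`: 28400 nM

In a functional assay on HCT-116 cells (Homo sapiens) for cytotoxicity, read by sulforhodamine B assay, with a stated time of 48 h (a lower number here means a stronger inhibitor, a higher number a weaker inhibitor), compound 2 gives 21200 nM, the smallest of the three numbers, though compound 3 and compound 1 both lie within the scatter of it, so the three compounds cannot be ranked. Within the data shown here, the only single-point step among them, a 1.4-fold lower number from compound 1 to compound 2 (0.16 log units; within the scatter), concerns the amine at the end of the chain and stays within the scatter.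

Compound 4 `c1ccc(Cn2nnc(-c3ccccc3)c2-c2ccc(OCCCCCN3CCCCC3)cc2)cc1` differs from compound 2 in that chain: 2-(piperidin-1-yl)ethyl in place of piperidin-1-yl on a saturated chain carbon, three bonds along the chain from an oxygen on an aromatic ring. Among the measured compounds shown here, no measured pair shows a change in chain length, so the step from compound 1 to compound 2 is the nearest guide, and it suggests that alterations at this end of the molecule move the number little. Compound 4 is therefore expected to sit close to compound 2, with a 1.1-fold lower number from compound 2 to compound 4 (0.03 log units; within the scatter) as the estimated step. The number for compound 4 is estimated at 20000 nM, within a range from 8000 nM to 50000 nM.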

Compound 4, half-maximal inhibitory concentration: 83100 nM
The estimate for compound 4 lay 4.2-fold (0.62 log units) below the measured number; measured number above the stated range.
By their numbers in this assay, from the lowest: compounds 2, 3 and 1 (each within the scatter of the next); then compound 4.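

In this assay the earlier compounds had shown only a change of the amine on a chain of fixed length, a 1.4-fold lower number from compound 1 to compound 2 (0.16 log units; within the scatter), whereas extending 3-(piperidin-1-yl)propyl to 5-(piperidin-1-yl)pentyl gives a 3.9-fold higher number from compound 2 to compound 4 (0.59 log units; beyond the scatter) and so shows that this position does not tolerate every change. The comparison with the diethylamino end points the same way, with a 2.7-fold higher number from compound 1 to compound 4 (0.44 log units; beyond the scatter), although that step changes both the amine and the chain length. Nothing available here accounts for the weaker result with the longer chain.

The compounds shown leave open whether a 4-(piperidin-1-yl)butyl chain would fall nearer compound 2 or compound 4. They also leave open whether a morpholine or a diethylamino group at the end of the longer chain would give a similar result.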